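The source may hold more compounds than are shown below. What is called first, only, known or untested is meant among the compounds shown, and "the series" means these compounds.

Working notes on the series. Compound 1 `O=C(/C=C\c1ccccc1)N1N=C(c2ccncc2)OC1c1c[nH]c2ccccc12` reaches only the limit in an ADME assay on HeLa cells (Homo sapiens) for cytotoxicity, read by MTT assay, with a stated time of 72 h; a lower number here means a stronger inhibitor of growth, a higher number a weaker inhibitor of growth: compound 1 gives > 30 ug/mL, which is a limit of the assay and not a number. Compound 2 `O=C(/C=C\c1cccc(Cl)c1)N1N=C(c2ccncc2)OC1c1c[nH]c2ccccc12` likewise stops at a limit in this assay, where compound 2 gives > 30 ug/mL. Compound 3 `O=C(/C=C/c1c(Cl)cccc1Cl)N1N=C(c2ccncc2)OC1c1c[nH]c2ccccc12` too stops at a limit in this assay, where compound 3 gives > 30 ug/mL. All three values sit at the limit of > 30 ug/mL in this assay, at which 3 of the 3 values shown sit, so compound 3 stands level with the other two as far as the numbers allow any reading; no ordering among them can be drawn.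

The next member, compound 4 `O=C(/C=C\c1cccc(Br)c1)N1N=C(c2ccncc2)OC1c1c[nH]c2ccccc12`, differs from compound 3 by 2-(3-bromophenyl)ethenyl in place of 2-(2,6-dichlorophenyl)ethenyl on a carbonyl carbon. The measured steps that touch this kind of change on the carbonyl carbon are a step that the two limits leave unreadable from compound 1 to compound 2, a step that the two limits leave unreadable from compound 1 to compound 3 and a step that the two limits leave unreadable from compound 2 to compound 3. None of them is readable in size, since both ends of each step sit at the limit of > 30 ug/mL in this assay, at which 3 of the 3 values shown sit. Nothing measured therefore points to a step beyond the scatter in either direction in this assay, and the most that can be said is that every halogenated analogue so far has stayed at the limit.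

Compound 4 is expected to give 45 ug/mL, with a range from 20 ug/mL to 120 ug/mL, most probably again reported as a limit rather than a number. The step that the limit leaves unreadable from compound 3 to compound 4 is accordingly estimated to lie within the scatter.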

Compound 4, concentration for 50% growth inhibition: > 30 ug/mL
Compound 4 ended at the assay's limit; the forecaster's own chance of this, stated with the estimate: 85%; the middle value lies beyond the limit too.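

In this assay compound 4 gives > 30 ug/mL, which is a limit of the assay and not a number. Within the data shown here, no step among compound 1, compound 2, compound 3 and compound 4 can be read in size: the limit of > 30 ug/mL in this assay, at which 4 of the 4 values shown sit. The compounds shown leave open whether any group on the carbonyl carbon gives a readable growth-inhibition value.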